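Pentan-3-yl on the shared core: compound 3 before measurement

The source may report more compounds than this note shows. Statements on the series, on what has been measured and on what is new or still open speak of the compounds shown alone.

Measured so far:
compound 1 `CCCc1nc2c(-c3ccccc3)cc(-c3ccccc3)nc2[nH]1`: 2.5 nM
compound 2 `c1ccc(-c2cc(-c3ccccc3)c3nc[nH]c3n2)cc1`: 1.2 nM

In an assay on CHO cells for displacement of a labelled ligand from adenosine receptor A1 (Homo sapiens) (a higher number here means a weaker inhibitor, a lower number a stronger inhibitor), compound 2 gives 1.2 nM, the lowest number of the two measured, with compound 1 nearest at 2.5 nM. Among the measured compounds shown here, the only step in hand is a 2.1-fold lower number from compound 1 to compound 2 (0.32 log units; beyond the scatter), so removing the propyl from the shared core lowered the number by a modest amount, beyond the scatter.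

Compound 3 `CCC(CC)c1nc2c(-c3ccccc3)cc(-c3ccccc3)nc2[nH]1` differs from compound 2 by pentan-3-yl in place of hydrogen on an aromatic carbon. The change runs the other way to the measured step, and the entering group is larger than the propyl that left between compound 1 and compound 2. On the basis of a 2.1-fold lower number from compound 1 to compound 2 (0.32 log units; beyond the scatter), the expectation for compound 3 is a modest rise in the number, of about the size seen in that step or somewhat more, rather than no change. For compound 3 the estimated step is a 3.3-fold higher number from compound 2 to compound 3 (0.52 log units; beyond the scatter). Compound 3 is therefore expected at 4 nM, with a range from 1.5 nM to 12 nM.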

Compound 3, inhibition constant: 0.87 nM
Compound 3: middle estimate off by 4.6-fold (0.66 log units), on the high side; the measured number lies below the stated range.
By their numbers in this assay, from the lowest: compounds 3 and 2 (each within the scatter of the next); then compound 1.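

In this assay, among the compounds shown here, the aromatic carbon between two ring nitrogen atoms carries pentan-3-yl as well as it carries hydrogen: a 1.4-fold lower number from compound 2 to compound 3 (0.14 log units; within the scatter) leaves the two compounds inseparable, whereas the earlier compounds offered only propyl here, which stood apart from hydrogen. Ethyl in place of hydrogen on the saturated chain carbon bound to the aromatic carbon gives a 2.9-fold lower number from compound 1 to compound 3 (0.46 log units; beyond the scatter), so the two alkyl groups do differ, and across hydrogen, propyl and pentan-3-yl the numbers do not follow chain size, with compound 1 the one that goes against such a trend. Nothing at hand explains why compound 1 stands apart from the other two.

On these data alone, whether this holds beyond plain hydrocarbon groups stays open: an amine or a carboxylic acid on this carbon could behave quite differently from the groups seen so far. A longer unbranched chain or a cyclopentyl ring would show whether the difference between propyl and pentan-3-yl goes with branching or with something else.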